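Halogen swap on the fused ring of compound 3

A few compounds are considered here, and "the series" means these few. Any claim that something is new, unique, unknown or untested is made for them only; others in the source may bear on it.

Compound 1 `Clc1cccc(NC2CCc3ccccc32)c1` gives 173 nM in an assay for inhibition of acyl-CoA (8-3)-desaturase (Homo sapiens); a higher number here means a weaker inhibitor, a lower number a stronger inhibitor. Compound 2 `Clc1cccc(Nc2n[nH]c3ccccc23)c1` gives 84 nM in this assay. Compound 3 `Fc1ccc2[nH]nc(Nc3cccc(Cl)c3)c2c1` gives 58 nM in this assay, the lowest of the three numbers; compound 2 sits within the scatter of it, whereas compound 1 stands beyond the scatter with a higher number. Among the compounds with values here, the only single-point step among the measured compounds is the introduction of fluoro onto the fused ring, a 1.4-fold lower number from compound 2 to compound 3 (0.16 log units; within the scatter), which did not move the number beyond the scatter.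

Compound 4 `Clc1cccc(Nc2n[nH]c3ccc(Cl)cc23)c1` differs from compound 3 by chloro in place of fluoro on an aromatic carbon. Within the data shown here, no measured pair shows chloro replacing fluoro at this place, so the step has no direct precedent. The step that bears on it is the one that put fluoro there, a 1.4-fold lower number from compound 2 to compound 3 (0.16 log units; within the scatter), and it stayed within the scatter. On that basis a step within the scatter is expected in this assay, with no direction called. Compound 4 is therefore estimated at 50 nM in this assay, with a range from 25 nM to 110 nM. The step this estimate implies, a 1.2-fold lower number from compound 3 to compound 4 (0.06 log units; within the scatter), is expected to lie within the scatter.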

Compound 4, half-maximal inhibitory concentration: 5 nM
Estimate against measurement, compound 4: 10-fold (1.00 log units) above, outside the stated range (below it).
By their numbers in this assay, from the lowest: compound 4; then compounds 3 and 2 (each within the scatter of the next); then compound 1.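

At this place on the fused ring, the choice of halogen matters in this assay: chloro in place of fluoro gives a large step (a 12-fold lower number from compound 3 to compound 4 (1.06 log units; beyond the scatter)), and chloro in place of hydrogen gives another (a 17-fold lower number from compound 2 to compound 4 (1.23 log units; beyond the scatter)), whereas fluoro in place of hydrogen stayed within the scatter (a 1.4-fold lower number from compound 2 to compound 3 (0.16 log units; within the scatter)). Compound 2 and compound 3 alone could not show that this position responds to substitution at all; compound 4 shows that it can, and that the response depends on which group enters. No measurement on hand bears on why chloro and fluoro part so sharply here, so the difference stands as an observation only.

A bromo, methyl, trifluoromethyl or methoxy group at this place would test whether the step is particular to chloro or is shared by other groups. Also open, on these data alone, is whether the step holds when the other chloro of compound 4, the one on the ring outside the fused system, gives way to a nitrile or a carboxylic acid.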